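Swapping the Substituted Phenyl for Thiophene on the Hydrazone

A few compounds are considered here, and "the series" means these few. Any claim that something is new, unique, unknown or untested is made for them only; others in the source may bear on it.

Compound 2 `C=CCc1cccc(/C=N/NC(=O)Nc2ccc(Oc3ccnc4cc(OCCCN5CCCCC5)c(OC)cc34)c(F)c2)c1OC` was tested in a functional assay on MDA-MB-231 cells (Homo sapiens) for cytotoxicity, read by MTT assay, with a stated time of 72 h (on this read-out higher numbers stand for weaker inhibition and lower numbers for stronger inhibition), where compound 2 gives 790 nM. That is the only number shown, since in this assay compound 1 `COc1ccc(/C=N/NC(=O)Nc2ccc(Oc3ccnc4cc(OCCCN5CCCCC5)c(OC)cc34)c(F)c2)c(OC)c1` gives "not determined" (no result reported). Compound 3 `COc1cc2c(Oc3ccc(NC(=O)N/N=C/c4cccs4)cc3F)ccnc2cc1OCCCN1CCCCC1` differs from compound 2 in a single place: thiophen-2-yl in place of 3-allyl-2-methoxyphenyl on a carbon with a double bond to nitrogen. Among the compounds with values here, no step between measured compounds is available to guide the guess, so the expected step of a 2.0-fold higher number from compound 2 to compound 3 (0.31 log units; beyond the scatter) is a modest weakening, barely beyond the usual scatter and uncertain in direction. Compound 3 is therefore estimated at 1600 nM, with a likely range from 500 nM to 5000 nM.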

Compound 3, half-maximal inhibitory concentration: 1260 nM
Compound 3: middle estimate off by 1.3-fold (0.10 log units), on the high side; the measured number falls inside the stated range.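

In this assay, replacing 3-allyl-2-methoxyphenyl with thiophen-2-yl gives a 1.6-fold higher number from compound 2 to compound 3 (0.20 log units; within the scatter), so the two compounds cannot be told apart on this read-out. At this carbon with a double bond to nitrogen, a group of 11 heavy atoms and a five-membered ring of 5 heavy atoms thus give results within the usual scatter. Nothing measured here bears on the reason for this result. Still open, from the compounds shown here alone, is how a furan-2-yl ring, a simple amine or a carboxylic acid at this place would compare with compound 3.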